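Extending the acid chain of compound 2

This account rests on a few compounds, and the source may have more. Where it says the series, first, only, none or still open, it means among the compounds named here.

Measured compounds:
compound 1 `O=C(O)c1ccc(NCc2cccc(Oc3ccccc3)c2)cc1` – 86%
compound 2 `Cc1nc(-c2ccc(C(F)(F)F)cc2)sc1CNc1ccc(C(=O)O)cc1` – 10%
compound 3 `O=C(O)CCCc1ccc(NCc2cccc(Oc3ccccc3)c2)cc1` – 59%

In a functional assay on CHO cells for agonist activity at Free fatty acid receptor 1 (Homo sapiens), read by a luciferase reporter (a higher number here means a larger maximal response, a lower number a smaller maximal response), compound 1 reaches 86% and compound 3 reaches 59%. Compound 2 gives 10%, which is the lowest of the three numbers, separated beyond the scatter from both compound 3 and compound 1.

Compound 4 `Cc1nc(-c2ccc(C(F)(F)F)cc2)sc1CNc1ccc(CCCC(=O)O)cc1` has not been measured. It differs from compound 2 in one place: 3-carboxypropyl in place of carboxy on an aromatic carbon.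

Among the compounds with values here, one measured step bears on this change. Between compound 1 and compound 3 the same exchange of carboxy for 3-carboxypropyl on the shared core of those two compounds gave a number 27 percentage points lower from compound 1 to compound 3 (beyond the scatter). That step, however, started from a high maximal response, whereas compound 2 already sits near the bottom of the scale, so there is little room for a comparable decrease. A change of the same sign is therefore expected for compound 4, but it is likely to stay within the scatter because compound 2 already gives 10%, a small number.

For compound 4 the expected step is a number 3 percentage points lower from compound 2 to compound 4 (within the scatter). The estimated maximal response of compound 4 in this assay is 7%, with a range from 0% to 28%.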

Compound 4, largest response reached (reported as percent of maximum), in percent of the reference or control that the assay uses: 44%
Compound 4: the middle estimate sits 37 percentage points below what was measured; measured number outside the range, above it.
By their numbers in this assay, from the lowest: compound 2; then compound 4; then compound 3; then compound 1.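

On an aromatic carbon para to a large group, the exchange of carboxy for 3-carboxypropyl has no single direction in this assay: on the core of compound 2 it gave a number 34 percentage points higher from compound 2 to compound 4 (beyond the scatter), the opposite sign to a number 27 percentage points lower from compound 1 to compound 3 (beyond the scatter). The outcome of this change therefore depends on the core that carries it, and the step on one core does not transfer to the other: the same change on two cores in this assay, a number 27 percentage points lower (beyond the scatter) from compound 1 to compound 3 and a number 34 percentage points higher (beyond the scatter) from compound 2 to compound 4, 61 percentage points apart, beyond the scatter of two such steps. The low number of compound 2 also proved to be no floor for this position, as the same exchange on that core produced a large rise in maximal response rather than a small further fall.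

The compounds shown hold only carboxy and 3-carboxypropyl at this position, so it remains open whether a 2-carboxyethyl group or a longer chain would raise or lower the maximal response on either core, and whether a tetrazole could stand in for the carboxylic acid. They also leave open which part of the two cores reverses the sign of the step, as the cores differ in more than one place.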